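This account rests on a few compounds, and the source may have more. Where it says the series, first, only, none or still open, it means among the compounds named here.

Compound 1 `CC(NC(=O)C#Cc1ccc(NC(=O)Nc2cc(C(F)(F)F)ccc2Cl)cc1)c1ccccc1`: 3170 nM
Compound 2 `CC(NC(=O)/C=C/c1ccc(NC(=O)Nc2ccc(Cl)c(C(F)(F)F)c2)cc1)c1ccccc1`: 1060 nM
Compound 3 `CC(NC(=O)C#Cc1ccc(NC(=O)Nc2ccc(Cl)c(C(F)(F)F)c2)cc1)c1ccccc1`: 4920 nM

These three compounds were tested in a functional assay on HT-29 cells (Homo sapiens) for inhibition, read by MTT assay, with a stated time of 120 h; a higher number here means a weaker inhibitor, a lower number a stronger inhibitor. Compound 2 gives the lowest number of the three, and its gap to compound 1 and to compound 3 lies beyond the usual scatter. Compound 4 `CC(NC(=O)/C=C/c1ccc(NC(=O)Nc2cc(C(F)(F)F)ccc2Cl)cc1)c1ccccc1` has not yet been measured in this assay. It differs from compound 2 by 2-chloro-5-(trifluoromethyl)phenyl in place of 4-chloro-3-(trifluoromethyl)phenyl on an amide-type nitrogen. The same change, at the same place, was already made once, giving a 1.6-fold lower number from compound 3 to compound 1 (0.19 log units; within the scatter). The difference between the core of compound 2 and the core of compound 3 is not broken down here. A step of similar size is expected for compound 4, a 1.3-fold lower number from compound 2 to compound 4 (0.12 log units; within the scatter), because the earlier step of a 1.6-fold lower number from compound 3 to compound 1 (0.19 log units; within the scatter) stayed within the scatter. Compound 4 is therefore estimated at 800 nM, with a likely range from 300 nM to 2500 nM.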

Compound 4, half-maximal inhibitory concentration: 4190 nM
Compound 4: the middle estimate sits 5.2-fold (0.72 log units) below what was measured, outside the stated range (above it).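

Putting 2-chloro-5-(trifluoromethyl)phenyl in place of 4-chloro-3-(trifluoromethyl)phenyl on the amide-type nitrogen gives a 4.0-fold higher number from compound 2 to compound 4 (0.60 log units; beyond the scatter) in this assay, so on the core of compound 2 this change gives a weaker inhibitor. Two cores cannot explain why the outcome depends on the core, nor predict the step on a further core. The change therefore did not carry over unchanged from one core to the other: the same change on two cores in this assay, a 1.6-fold lower number (0.19 log units; within the scatter) from compound 3 to compound 1 and a 4.0-fold higher number (0.60 log units; beyond the scatter) from compound 2 to compound 4, 6.1-fold (0.79 log units) apart, beyond the scatter of two such steps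

The compounds shown leave open how these two groups would compare with another link between the amide and the urea, such as a saturated two-carbon chain. They also leave open whether an amine or a carboxylic acid in place of the chlorine would alter the step.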